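Terminal amine variation on the thiazole urea side chain

The source may hold more compounds than are shown below. What is called first, only, known or untested is meant among the compounds shown, and "the series" means these compounds.

Measured so far in a functional assay on HCT-116 cells (Homo sapiens) for antiproliferative activity, read by MTT assay, with a stated time of 72 h; on this read-out lower numbers stand for stronger inhibition and higher numbers for weaker inhibition:
- compound 1 `COc1ncc(-c2ccc3nc(NC(=O)NCCN4CCCCC4)sc3c2)cc1NS(=O)(=O)c1ccc(F)cc1` gives 610 nM
- compound 2 `COc1ncc(-c2ccc3nc(NC(=O)NCCN4CCCC4)sc3c2)cc1NS(=O)(=O)c1ccc(F)cc1` gives 310 nM
- compound 3 `COc1ncc(-c2ccc3nc(NC(=O)NCCN4CCN(C)CC4)sc3c2)cc1NS(=O)(=O)c1ccc(F)cc1` gives 540 nM

All three share one core and differ only in the amine at the end of the urea side chain. Compound 3 holds the second highest of the three numbers, sitting nearest compound 1 and furthest from compound 2, with every gap within the scatter.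

The next compound, compound 4 `COc1ncc(-c2ccc3nc(NC(=O)NCCN(C)C)sc3c2)cc1NS(=O)(=O)c1ccc(F)cc1`, is not yet measured. It differs from compound 3 by dimethylamino in place of 4-methylpiperazin-1-yl on a saturated chain carbon, two bonds along the chain from an amide-type nitrogen

Among the compounds with values here, two measured steps touch the same position: a 1.1-fold lower number from compound 1 to compound 3 (0.05 log units; within the scatter) and a 1.7-fold higher number from compound 2 to compound 3 (0.24 log units; within the scatter). The third, a 2.0-fold lower number from compound 1 to compound 2 (0.29 log units; within the scatter), is also small. Every swap of the terminal amine so far has stayed within the scatter, so no step beyond it is expected for the change to dimethylamino, and compound 4 is expected to give a 1.2-fold lower number from compound 3 to compound 4 (0.08 log units; within the scatter) in this assay. Compound 4 is therefore estimated at 450 nM, with a range from 200 nM to 1100 nM.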

Compound 4, half-maximal inhibitory concentration: 240 nM
Beside the measured number, compound 4's estimate is 1.9-fold (0.27 log units) above it; measured number inside the range.
By their numbers in this assay, from the lowest: compounds 4, 2, 3 and 1 (each within the scatter of the next, the first and the last beyond it).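

In this assay, within the data shown here, dimethylamino, which carries no ring, gives the first steps at this position that lie beyond the scatter, both modest (a 2.3-fold lower number from compound 3 to compound 4 (0.35 log units; beyond the scatter) and a 2.5-fold lower number from compound 1 to compound 4 (0.41 log units; beyond the scatter)), so the terminal amine on this saturated chain carbon is not silent. The pattern does not cover all the ring amines: compound 2, with pyrrolidin-1-yl, goes against it, since its step stays within the scatter (a 1.3-fold lower number from compound 2 to compound 4 (0.11 log units; within the scatter)), and the absence of a ring alone does not set compound 4 apart. Nothing available here bears on what lies behind these steps.

Open, from the compounds shown here alone, is whether diethylamino or morpholin-4-yl at this position would fall with compound 4 or with compound 1. Also open, going by these compounds, is how a longer chain between the urea and dimethylamino would read in this assay.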